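The source may report more compounds than this note shows. Statements on the series, on what has been measured and on what is new or still open speak of the compounds shown alone.

Compound 2 `CN(C)c1cccc(OCCCn2cnc(-c3ccccc3)c2)c1NC(=O)NC1CCCC1` gives 3530 nM in an assay on aorta for inhibition of acyl-CoA:cholesterol acyltransferase (Oryctolagus cuniculus); on this read-out higher numbers stand for weaker inhibition and lower numbers for stronger inhibition. Compound 1 `CCCCNC(=O)Nc1c(OCCCn2cnc(-c3ccccc3)c2)cccc1N(C)C` gives 810 nM in this assay. Among the measured compounds shown here, the single step measured so far, a 4.4-fold higher number from compound 1 to compound 2 (0.64 log units; beyond the scatter), leaves compound 2 with the highest of the two numbers in this assay, compound 1 being its nearest neighbour. Compound 3 `CCCCCN(C)C(=O)Nc1c(OCCCn2cnc(-c3ccccc3)c2)cccc1N(C)C` is the next member; it differs from compound 2 by methyl(pentyl)amino in place of cyclopentylamino on a carbonyl carbon. Only a 4.4-fold higher number from compound 1 to compound 2 (0.64 log units; beyond the scatter) bears on this change, and it did so in the opposite sense, a chain giving way to a ring; compound 3 goes back to a chain. For the measured compounds named here, the group that enters, however, has no hydrogen-bond donor, and no measured pair covers that part of the change, so the outcome is uncertain. Compound 3 is expected to give about 1500 nM in this assay, with a range from 400 nM to 6000 nM. The expected step is a 2.4-fold lower number from compound 2 to compound 3 (0.37 log units; beyond the scatter).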

Compound 3, half-maximal inhibitory concentration: 280 nM
Estimate against measurement, compound 3: 5.4-fold (0.73 log units) above; measured number below the stated range.
By their numbers in this assay, from the lowest: compound 3; then compound 1; then compound 2.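

In this assay the carbonyl carbon's amino group can lose the amide hydrogen without any loss of inhibition: there is a 13-fold lower number from compound 2 to compound 3 (1.10 log units; beyond the scatter) and also a 2.9-fold lower number from compound 1 to compound 3 (0.46 log units; beyond the scatter) with methyl(pentyl)amino in place. Compound 3 therefore has the lowest number of the three, with both steps beyond the scatter, and the absence of a hydrogen-bond donor on this group does not count against it. Both open-chain compounds, compound 1 and compound 3, stand below the ring-bearing compound 2, and no supporting data explain these steps.

Methyl(pentyl)amino differs from butylamino in both chain length and the added methyl, so the shares of these two changes stay unresolved. Pentylamino and methyl(butyl)amino would separate them, and a longer chain such as methyl(hexyl)amino would show whether the trend continues.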